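This account rests on a few compounds, and the source may have more. Where it says the series, first, only, none or still open, it means among the compounds named here.

In an in vitro ADME assay on microsomes from liver (Homo sapiens) for metabolic stability, read by LC-MS, tested at 1 uM (on this read-out lower numbers stand for slow clearance and higher numbers for fast clearance), compound 3 `COCCNS(=O)(=O)c1ccc(C)c(C#Cc2cc(Cl)ccc2OCC(=O)O)c1` sits at the limit of < 10 mL.min-1.g-1 in this assay, at which 1 of the 3 values shown sits, so for compound 3 only a limit of the assay, not a number, is known: < 10 mL.min-1.g-1. Compound 1 `COCCN(C)S(=O)(=O)c1ccc(C)c(C#Cc2cc(Cl)ccc2OCC(=O)O)c1` gives 32 mL.min-1.g-1, and compound 2 `Cc1ccc(S(=O)(=O)N(C)CC(C)C)cc1C#Cc1cc(Cl)ccc1OCC(=O)O` gives 79 mL.min-1.g-1. Compound 4 `Cc1ccc(S(=O)(=O)N(C)C)cc1C#Cc1cc(Cl)ccc1OCC(=O)O` differs from compound 3 by dimethylamino in place of (2-methoxyethyl)amino on a sulfonyl sulfur. For the measured compounds named here, two measured steps bear on this change: an at least 3.2-fold lower number from compound 1 to compound 3 (0.50 log units; beyond the scatter), and an at least 7.9-fold lower number from compound 2 to compound 3 (0.89 log units; beyond the scatter). Both point the same way, so removing the (2-methoxyethyl)amino group is expected to raise the number, by about an at least 2.5-fold higher number from compound 3 to compound 4 (0.39 log units; beyond the scatter), though dimethylamino is a smaller group than those in a 2.5-fold higher number from compound 1 to compound 2 (0.39 log units; beyond the scatter), so a rise as large as that one is not expected. Compound 4 is therefore expected to give 25 mL.min-1.g-1, between 10 mL.min-1.g-1 and 60 mL.min-1.g-1.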

Compound 4, intrinsic clearance in microsomes: < 10 mL.min-1.g-1
Compound 4 gave a limit, no number (the forecaster's own chance of this, stated with the estimate: 20%); at least 2.5-fold (0.39 log units) between middle value and limit.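

Compound 4 has no hydrogen on the sulfonamide nitrogen, yet in this assay compound 4 also sits at a limit rather than a number: the limit of < 10 mL.min-1.g-1 in this assay, at which 2 of the 4 values shown sit. So that hydrogen is not needed for slow clearance, and replacing the longer chain on the nitrogen with methyl gives an at least 3.2-fold lower number from compound 1 to compound 4 (0.50 log units; beyond the scatter) and an at least 7.9-fold lower number from compound 2 to compound 4 (0.89 log units; beyond the scatter). The step between compound 3 and compound 4 cannot be read, as both values are limits.

Which of these two clears more slowly stays open. Also open, going by these compounds, is whether an ethyl group or a morpholine ring on the sulfonyl sulfur would keep clearance this slow.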